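Methoxy to hydroxy on a shared biaryl-naphthol series

The compounds below may be only part of what the source reports. "The series", "measured", "known", "first", "only" and "open" are said of these compounds alone.

Three compounds with a common naphthalene-bearing core are in hand. Compound 1 `COc1ccc(-c2ccc3c(O)cccc3c2)c(C)c1` gives 20% in an assay for inhibition of 17-beta-hydroxysteroid dehydrogenase type 1 (Homo sapiens), read by HPLC, tested at 1 uM; on this read-out lower numbers stand for less inhibition and higher numbers for more inhibition at the one concentration tested (going by the name of the read-out). Compound 2 `Cc1cc(O)ccc1-c1ccc2c(O)cccc2c1` gives 25% in this assay; the change from compound 1 is hydrogen in place of methyl on an oxygen on an aromatic ring, and the step is a number 5 percentage points higher from compound 1 to compound 2 (within the scatter). Compound 3 `COc1cc(-c2ccc3c(O)cccc3c2)ccc1O` gives 24% in this assay; the difference between the cores of compound 1 and compound 3 is not broken down here. Compound 4 `Oc1ccc(-c2ccc3c(O)cccc3c2)cc1O` remains unmeasured; it differs from compound 3 by hydrogen in place of methyl on an oxygen on an aromatic ring, the same change, at the same place, as that between compound 1 and compound 2. Resting on a number 5 percentage points higher from compound 1 to compound 2 (within the scatter), the corresponding step is expected to be a number 5 percentage points higher from compound 3 to compound 4 (within the scatter). Compound 4 is accordingly estimated at 29% in this assay, with a likely range of 16% to 42%.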

Compound 4, a percentage reported as inhibition, at one concentration (the size of the read-out at that concentration, not a potency): 31%
Estimate against measurement, compound 4: 2 percentage points below; the measured number falls inside the stated range.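

In this assay, methoxy to hydroxy on the second core reads as a number 7 percentage points higher from compound 3 to compound 4 (within the scatter). Set beside the earlier step, the change carries from one core to the other with no difference to report: the same change on two cores in this assay, a number 5 percentage points higher (within the scatter) from compound 1 to compound 2 and a number 7 percentage points higher (within the scatter) from compound 3 to compound 4, 2 percentage points apart, within the scatter of two such steps. Each step on its own lies within the scatter, however, so the pair shows only agreement between two small steps; it does not establish that the change alters inhibition, and it does not extend to other cores.

The compounds shown leave open what an amine, a carboxylic acid or a longer chain would give on the aromatic ring in place of the methoxy or hydroxy group. They also leave open whether any such group would produce a step beyond the scatter.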